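The source may hold more compounds than are shown below. What is called first, only, known or untested is meant among the compounds shown, and "the series" means these compounds.

Working notes on the series.

Compound 1 has the structure `CCC(C)Sc1nc(O)cc(C(C)c2ccccc2)n1` and compound 2 the structure `CC(c1ccccc1)c1cc(O)nc(SC2CCCCC2)n1`. In a functional assay on MT4 cells (Homo sapiens) for cytotoxicity (a higher number here means that more compound is tolerated, a lower number that less compound is tolerated), compound 1 gives 200000 nM. In the same assay compound 2 gives 149000 nM. The two structures differ by cyclohexyl in place of sec-butyl on a sulfur, and the measured step is a 1.3-fold lower number from compound 1 to compound 2 (0.13 log units; within the scatter).

Compound 3 has the structure `CCC(C)Sc1nc(O)cc(C(C)c2c(F)cccc2F)n1`. In this assay compound 3 gives only a limit, > 200000 nM. That reading is the limit of > 200000 nM in this assay, at which 1 of the 3 values shown sits. The difference between the core of compound 3 and the core of compound 1 is not broken down here.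

Compound 4, the structure `CC(c1cc(O)nc(SC2CCCCC2)n1)c1c(F)cccc1F`, has not yet been measured in this assay. Compound 4 differs from compound 3 by cyclohexyl in place of sec-butyl on a sulfur. The place of the change reads the same as for the pair of compound 1 and compound 2, so this is the same change, made for the second time among the four compounds shown.

The expected step is a number no higher from compound 3 to compound 4 (the limit leaves the size open), and it rests on the earlier step of a 1.3-fold lower number from compound 1 to compound 2 (0.13 log units; within the scatter), which lay within the scatter. Since compound 3 is known only as a limit, the estimate for compound 4 carries a fair chance of coming back as a limit too. For compound 4 the estimate in this assay is 200000 nM, with a range from 110000 nM to 400000 nM.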

Compound 4, half-maximal cytotoxic concentration: > 200000 nM
Compound 4: no number, only a limit; the forecaster's own chance of this, stated with the estimate: 50%; the middle value sits exactly at the limit.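

In this assay compound 4 gives > 200000 nM, which is a limit of the assay and not a number. Cyclohexyl in place of sec-butyl on a sulfur therefore cannot be sized on the core of compound 3, and the step from compound 3 to compound 4 cannot be read, as both compounds stand at a limit: the limit of > 200000 nM in this assay, at which 2 of the 4 values shown sit. The only readable new step, an at least 1.3-fold higher number from compound 2 to compound 4 (0.12 log units; that floor lies within the scatter), belongs to 2,6-difluorophenyl in place of phenyl and does not size the sulfur change, so the data neither confirm nor refute that the earlier step, a 1.3-fold lower number from compound 1 to compound 2 (0.13 log units; within the scatter), carries over from the core of compound 1 to the core of compound 3.

The compounds shown leave open how far past the limit compound 3 and compound 4 lie, and so whether the cyclohexyl change has any measurable size on the core of compound 3. Also open, from the compounds shown here alone, is how this assay reads a different kind of group on the sulfur, such as a longer chain or a chain ending in an amine, on either core.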